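A few compounds are considered here, and "the series" means these few. Any claim that something is new, unique, unknown or untested is made for them only; others in the source may bear on it.

Two compounds have been measured in an ADME assay on PC-3 cells (Homo sapiens) for cytotoxicity, read by WST assay, tested at 100 uM; on this read-out higher numbers stand for more inhibition at the one concentration tested (going by the name of the read-out) and lower numbers for less inhibition:

Compound 1 `CSc1cccc(NC(=O)C2CCCN(C(=O)c3cc(C(F)(F)F)cc(C(F)(F)F)c3)C2)c1`: compound 1 gives 0%.
Compound 2 `CC(C)(C)CC(=O)Nc1cccc(C(=O)N2CCCC(C(=O)Nc3ccc(Cl)cc3)C2)c1`: compound 2 gives 0%.

On these numbers compound 2 stands level with compound 1 at the digits shown; the two values lie within the usual scatter of each other, so no order between them can be read. Compound 3 `O=C(Nc1ccc(Cl)cc1)C1CCCN(C(=O)c2cccc(-c3cnco3)c2)C1` differs from compound 2 in one place: 1,3-oxazol-5-yl in place of (neopentylcarbonyl)amino on an aromatic carbon. Within the data shown here, no step between measured compounds is known that could guide this change, and both measured values sit at the bottom of the scale, so no movement beyond the scatter is expected in this assay. For compound 3 the expected value is 0%, with a range from -10% to 12%. The step this estimate means, no change at the digits printed from compound 2 to compound 3 (within the scatter), is expected to be none beyond the scatter.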

Compound 3, a percentage reported as inhibition, at one concentration (the size of the read-out at that concentration, not a potency): 0%
Compound 3: the middle estimate sits on the measured number at the digits printed; the measured number falls inside the stated range.
By their numbers in this assay, from the lowest: compounds 1, 2 and 3 (each within the scatter of the next).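

Putting 1,3-oxazol-5-yl in place of (neopentylcarbonyl)amino on this aromatic carbon gives, in this assay, no change at the digits printed from compound 2 to compound 3 (within the scatter). Among these compounds, this is the first step that can be read at this position: an open chain with no ring and a five-membered aromatic ring leave the read-out in the same place, at the bottom of the scale. No measured evidence bears on this result.

From the compounds shown here alone, whether an amine or a carboxylic acid on this carbon would raise the value in this assay stays open. With every value at the bottom of the scale, the compounds shown do not reveal which changes could move it.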